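Swapping a pyrazole for a fluorophenyl on a pyridine core

This account rests on a few compounds, and the source may have more. Where it says the series, first, only, none or still open, it means among the compounds named here.

Three compounds share the same amide-linked dimethoxypyridine tail. Compound 1 `COc1ccc(CNC(=O)c2cc(-c3cncc(C)c3)ncc2-c2cnn(C)c2)nc1OC` gives 10000 nM in an assay on CHO cells for antagonist activity at Orexin/Hypocretin receptor type 1 variant I408V (Homo sapiens), read by FLIPR, with a stated time of 5 min (a higher number here means a weaker inhibitor, a lower number a stronger inhibitor), the highest of the two numbers measured. Compound 2 `COc1ccc(CNC(=O)c2cc(-c3cncc(C)c3)ccc2-c2ccccc2)nc1OC` gives 1540 nM in this assay. Compound 3 `COc1ccc(CNC(=O)c2sc(-c3cncc(C)c3)nc2-c2cccc(F)c2)nc1OC` reaches only the limit of > 10000 nM in this assay, so it yields no exact number; this is the limit (the limit of > 10000 nM in this assay, at which 1 of the 3 values shown sits).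

Compound 4 `COc1ccc(CNC(=O)c2cc(-c3cncc(C)c3)ncc2-c2ccccc2F)nc1OC` is not yet measured. It differs from compound 1 in one place: 2-fluorophenyl in place of 1-methyl-1H-pyrazol-4-yl on an aromatic carbon. Compound 2, which carries a plain phenyl ring, gave a lower number than compound 1, so a step of similar direction is expected here. The step from compound 1 to compound 4 is estimated at a 3.3-fold lower number from compound 1 to compound 4 (0.52 log units; beyond the scatter), giving compound 4 an expected value of about 3000 nM, between 1000 nM and 10000 nM.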

Compound 4, half-maximal inhibitory concentration: 3000 nM
Estimate against measurement, compound 4: no gap at the digits printed; low and high end bracket the measured number.
By their numbers in this assay, from the lowest: compounds 2 and 4 (each within the scatter of the next); then compound 1.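

For the compounds shown here, at this position, on an aromatic carbon ortho to a large group, the earlier compounds offered no one-place comparison; now replacing 1-methyl-1H-pyrazol-4-yl with 2-fluorophenyl gives a 3.3-fold lower number from compound 1 to compound 4 (0.52 log units; beyond the scatter) in this assay. Going by these compounds alone, the single change swaps a ring with two hydrogen-bond acceptors for a carbon-only ring that also carries fluorine, so the step cannot be assigned to either feature alone. No measurement shown here explains the step.

From the compounds shown here alone, the share of the fluorine in this step remains open. So does the outcome with a morpholine or a carboxylic acid at this position.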